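The source may report more compounds than this note shows. Statements on the series, on what has been measured and on what is new or still open speak of the compounds shown alone.

Compound 3 `C#CCCOC(=O)C1=C(C)NC(C)=C(C(=O)OC)C1c1cccc([N+](=O)[O-])c1` gives 35 nM in a functional assay on HEK293 cells for antagonist activity at Voltage-dependent L-type calcium channel subunit alpha-1D (Rattus norvegicus), read by FLIPR; on this read-out higher numbers stand for weaker inhibition and lower numbers for stronger inhibition. Its number is the lowest of the three measured, yet it sits within the scatter of compound 2 `CCOC(=O)C1=C(C)NC(COC(C)=O)=C(C(=O)OCC)C1c1cccc([N+](=O)[O-])c1`, which gives 37 nM in this assay, and of compound 1 `CCOC(=O)C1=C(C)NC(CCl)=C(C(=O)OCC)C1c1cccc([N+](=O)[O-])c1`, which gives 53 nM in this assay. Compound 4 `COC(=O)C1=C(C)NC(C)=C(C(=O)OCCOCc2ccccc2)C1c1cccc([N+](=O)[O-])c1` differs from compound 3 in one place: benzyloxy in place of ethynyl on a saturated chain carbon, two bonds along the chain from an oxygen next to a carbonyl group. Within the data shown here, the only measured step, a 1.4-fold lower number from compound 1 to compound 2 (0.16 log units; within the scatter), concerns a different part of the shared core and therefore says little about an exchange on the ester chain. Among the measured compounds shown here, with no measured step bearing directly on this change, compound 4 is expected to show a 1.2-fold lower number from compound 3 to compound 4 (0.07 log units; within the scatter), that is, nothing beyond the scatter. The estimate for compound 4 is 30 nM, with a range from 8 nM to 120 nM.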

Compound 4, half-maximal inhibitory concentration: 12 nM
For compound 4 the middle estimate is 2.5-fold (0.40 log units) above the measured one; the measured number falls inside the stated range.
By their numbers in this assay, from the lowest: compound 4; then compounds 3, 2 and 1 (each within the scatter of the next).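

On this ester chain, benzyloxy in place of ethynyl gives a 2.9-fold lower number from compound 3 to compound 4 (0.46 log units; beyond the scatter) in this assay, the first step shown that lies beyond the scatter. The only earlier step lay within the scatter and concerned another part of the shared core, so this chain is the one place shown where a single change moves the number, and a group of eight heavy atoms with an aromatic ring is accepted here. No evidence bears on the reason for this step.

Benzyloxy brings its ring, its oxygen and its greater length together, and the compounds shown do not separate them. As far as these compounds go, how an amine or a carboxylic acid at the end of this chain would read also stays open.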